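Adding a Second Methoxy Group: Expected Effect on Growth Inhibition

The source may hold more compounds than are shown below. What is called first, only, known or untested is meant among the compounds shown, and "the series" means these compounds.

Of the compounds shown here, two have been measured for their ability to slow the growth of lung cancer cells. Compound 1 `COc1ccc(-c2cc(/C=C/C(=O)c3ccc(C)cc3)nc3cc(-c4ccccc4)nn23)cc1OC` gives 17200 nM in a functional assay on A549 cells (Homo sapiens) for antiproliferative activity, read by MTT assay, with a stated time of 24 h; a lower number here means a stronger inhibitor, a higher number a weaker inhibitor. Compound 2 `COc1ccc(-c2cc(/C=C/C(=O)c3ccccc3)nc3cc(-c4ccccc4)nn23)cc1` gives 8600 nM in this assay and stands at the lower of the two numbers, although the gap to compound 1 lies within the scatter of repeated measurements, so the two cannot be told apart with confidence. Compound 3 `COc1ccc(-c2cc(/C=C/C(=O)c3ccccc3)nc3cc(-c4ccccc4)nn23)cc1OC` has not yet been measured. It differs from compound 2 by methoxy in place of hydrogen on an aromatic carbon, a change read as 4-methoxyphenyl to 3,4-dimethoxyphenyl. Compound 1 already carries that dimethoxy pattern together with a methyl on the other aromatic ring, and its value in this assay sits close to that of compound 2. The expected step from compound 2 to compound 3 is therefore small, a 1.4-fold higher number from compound 2 to compound 3 (0.14 log units; within the scatter), pointing to a slightly weaker inhibitor but not beyond the scatter. Compound 3 is estimated at 12000 nM, with a range from 5000 nM to 30000 nM.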

Compound 3, half-maximal inhibitory concentration: 10700 nM
For compound 3 the middle estimate is 1.1-fold (0.05 log units) above the measured one; measured number inside the range.
By their numbers in this assay, from the lowest: compounds 2, 3 and 1 (each within the scatter of the next).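

In this assay, methoxy in place of hydrogen on an aromatic carbon, ortho to a methoxy group, leaves the two compounds within the scatter of each other (a 1.2-fold higher number from compound 2 to compound 3 (0.09 log units; within the scatter)), so 4-methoxyphenyl and 3,4-dimethoxyphenyl cannot be told apart here. The second comparison isolates the methyl group, which until now came together with the second methoxy group, and hydrogen in place of methyl also stays within the scatter (a 1.6-fold lower number from compound 1 to compound 3 (0.21 log units; within the scatter)). No measurement at hand explains either result.

The compounds shown carry only hydrogen or methoxy at the first place and only hydrogen or methyl at the second, so what an amine or a carboxylic acid would do at either place remains open. Also open, going by these compounds, is whether any change at these two places can move the number beyond the scatter.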